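The source may report more compounds than this note shows. Statements on the series, on what has been measured and on what is new or still open speak of the compounds shown alone.

Measured so far in an ADME assay on MDBK cells (Bos taurus) for cytotoxicity, read by MTT assay, with a stated time of 96 h; on this read-out lower numbers stand for higher toxicity in this test and higher numbers for lower toxicity in this test:
compound 1, `Oc1ccc(-c2nc3cc(C(F)(F)F)ccc3[nH]2)cc1`: 51000 nM
compound 2, `CN1CCN(CC(=O)Nc2ccc(-c3nc4cc(C(F)(F)F)ccc4n3C)cc2)CC1`: 44000 nM
compound 3, `Cn1c(-c2ccc(NC(=O)CN3CCCC3)cc2)nc2cc(C(F)(F)F)ccc21`: 65000 nM

The three numbers sit close together. Compound 1 stands second highest of the three; compound 2 is nearest to it and compound 3 furthest, and both gaps lie within the scatter. For the measured compounds named here, the only step between compounds that differ in one place, a 1.5-fold higher number from compound 2 to compound 3 (0.17 log units; within the scatter), also lies within the scatter, and it concerns an exchange on the amide side chain of the shared core, not the phenol side.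

Compound 4, `COc1ccc(-c2nc3cc(C(F)(F)F)ccc3[nH]2)cc1`, differs from compound 1 by methyl in place of hydrogen on an oxygen on an aromatic ring. Going by the values given here, no measured step touches this position, so nothing in the data speaks for a shift in either direction; the one step that exists shows a change elsewhere leaving this assay essentially flat. The expectation for compound 4 is therefore a step of a 1.0-fold lower number from compound 1 to compound 4 (0.01 log units; within the scatter), no more than the scatter. The estimated value for compound 4 is 50000 nM, with a range from 25000 nM to 100000 nM.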

Compound 4, half-maximal cytotoxic concentration: > 100000 nM
Compound 4: no number, only a limit; the forecaster's own chance of this, stated with the estimate: 20%; at least 2.0-fold (0.30 log units) between middle value and limit.
By their numbers in this assay, from the lowest: compounds 2, 1 and 3 (each within the scatter of the next). At a limit, above all of these: compound 4.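

In this assay compound 4 gives > 100000 nM, which is a limit of the assay and not a number. For the compounds shown here, this is the first reading at this position, and hydroxy to methoxy on the aromatic ring gives an at least 1.9-fold higher number from compound 1 to compound 4 (0.29 log units; that floor lies within the scatter), so the direction is upward, but the step cannot be claimed as beyond the scatter. Compound 4 alone among the compounds shown stands at the limit, so the true size of the step stays unknown: the limit of > 100000 nM in this assay, at which 1 of the 4 values shown sits.

Going by these compounds, whether a longer chain on this oxygen, such as ethoxy, would read like methoxy remains open. So does the effect of an amine or a carboxylic acid in place of the hydroxy, which would show whether this position tolerates more than a methyl in this assay.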